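This account rests on a few compounds, and the source may have more. Where it says the series, first, only, none or still open, it means among the compounds named here.

In a functional assay on HCT-116 cells (Homo sapiens) for inhibition, read by MTT assay, with a stated time of 72 h (a lower number here means a stronger inhibitor, a higher number a weaker inhibitor), compound 3 `COc1ccc(CCCNCc2c(OC)cc(Oc3cccc(Nc4ccccc4)c3)cc2OC)cc1` gives 2850 nM, and compound 1 `COc1cc(Oc2cccc(Nc3ccccc3)c2)cc(OC)c1CNCc1ccc(F)cc1` gives 4220 nM. These two sit level, with a 1.5-fold lower number from compound 1 to compound 3 (0.17 log units; within the scatter). Compound 2 `CNCc1c(OC)cc(Oc2cccc(Nc3ccccc3)c2)cc1OC` is reported only as a limit of the assay, > 20000 nM. Compound 4 `COc1cc(Oc2cccc(Nc3ccccc3)c2)cc(OC)c1CN(C)C` differs from compound 3 by dimethylamino in place of (3-(4-methoxyphenyl)propyl)amino on a saturated chain carbon bound to an aromatic carbon. The nearest measured changes are an at least 7.0-fold lower number from compound 2 to compound 3 (0.84 log units; beyond the scatter) and an at least 4.7-fold higher number from compound 1 to compound 2 (0.67 log units; beyond the scatter), both showing that the small amine of compound 2 sits on the weak side. A step of similar size towards a higher number is therefore expected in this assay, estimated as a 6.0-fold higher number from compound 3 to compound 4 (0.78 log units; beyond the scatter). For compound 4 the estimate is 17000 nM, with an expected range of 7000 nM to 35000 nM.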

Compound 4, half-maximal inhibitory concentration: 12900 nM
Estimate against measurement, compound 4: 1.3-fold (0.12 log units) above; the measured number falls inside the stated range.
By their numbers in this assay, from the lowest: compounds 3 and 1 (each within the scatter of the next); then compound 4. At a limit, above all of these: compound 2.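

In this assay the small amine now has a real number: dimethylamino gives a 4.5-fold higher number from compound 3 to compound 4 (0.66 log units; beyond the scatter) and a 3.1-fold higher number from compound 1 to compound 4 (0.49 log units; beyond the scatter) on this saturated chain carbon bound to an aromatic carbon, so compound 1 and compound 3 both stand on the stronger side of it. Compound 2 is a limit and not a number, so an at least 1.5-fold lower number from compound 2 to compound 4 (0.19 log units; that floor lies within the scatter) is only a floor, and methyl in place of hydrogen on an amine nitrogen cannot be read.

Still open, from the compounds shown here alone, is whether the aromatic ring or the chain length carries the gain, which a plain hexyl chain on the amine would separate.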